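Trading an Ether Linker for a Cis Double Bond

The source may hold more compounds than are shown below. What is called first, only, known or untested is meant among the compounds shown, and "the series" means these compounds.

Within the data shown here, compound 1 `O=C(O)COCCCCC1=CCC[C@@H]1CNS(=O)(=O)c1ccc(F)cc1` is the only compound here that stands on a single number: in a functional assay on a cell-free system (plasma) for inhibition of thromboxane A2 receptor (Homo sapiens), read by turbidimetry (on this read-out higher numbers stand for weaker inhibition and lower numbers for stronger inhibition), compound 1 gives 200 nM. The other measured compound, compound 2 `O=C(O)CCC/C=C\CC1=CCC[C@@H]1NS(=O)(=O)c1ccc(F)cc1`, carries two entries; in this assay compound 2 gives 4400 nM; 4400 nM (2 entries). Compound 2 differs from compound 1 in more than one place, so its two values show only that it inhibits more weakly, not which feature is responsible.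

Compound 3 `O=C(O)CC/C=C\CC1=CCC[C@@H]1CNS(=O)(=O)c1ccc(F)cc1` is not yet measured. Compared with compound 1 it changes in one place: 4-carboxybut-1-en-1-yl in place of 3-(carboxymethoxy)propyl on a saturated chain carbon bound to a double-bonded ring carbon. Among the measured compounds shown here, no single-point step between measured compounds exists to guide this change, so the expected step from compound 1 to compound 3 is modest and towards weaker inhibition, near the edge of the usual scatter, as a 1.8-fold higher number from compound 1 to compound 3 (0.24 log units; within the scatter) expresses. Compound 3 is therefore estimated to give 350 nM in this assay, with a likely range from 80 nM to 1500 nM.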

Compound 3, half-maximal inhibitory concentration: 600 nM
The estimate for compound 3 lay 1.7-fold (0.23 log units) below the measured number, within the range that was stated.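

Among these compounds, replacing 3-(carboxymethoxy)propyl with 4-carboxybut-1-en-1-yl on the saturated chain carbon bound to a double-bonded ring carbon gives the first single-change reading in this assay, a modest step of a 3.0-fold higher number from compound 1 to compound 3 (0.48 log units; beyond the scatter) that lies beyond the usual scatter. The two chains are therefore not interchangeable at this position, although the change weakens inhibition only modestly. Nothing measured here explains the difference.

This one step swaps the chain's ether oxygen and adds a cis double bond together, so the compounds shown leave open which of the two changes accounts for the weaker inhibition. A saturated 4-carboxybutyl group at the same place, with neither the ether oxygen nor the double bond, would help to separate them.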